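Piperidine methyl removal in the imide series

The source may hold more compounds than are shown below. What is called first, only, known or untested is meant among the compounds shown, and "the series" means these compounds.

Compound 1 `CCN1C(=O)CN(Cc2ccc(-c3ccc(F)c(CN4CCCCC4)n3)cc2)C1=O`, compound 2 `O=C1CN(Cc2ccc(-c3ccc(F)c(CN4CCCCC4)n3)cc2)C(=O)N1CC1CCC1` and compound 3 `CC(C)CN1C(=O)CN(Cc2ccc(-c3ccc(F)c(CN4CCCC(C)C4)n3)cc2)C1=O` share one core and were run in an in vitro ADME assay on microsomes from liver (Rattus norvegicus) for metabolic stability, read by LC-MS, using NADPH, tested at 1 uM; on this read-out lower numbers stand for a shorter-lived compound and higher numbers for a longer-lived compound. Compound 1 gives 0.517 h, compound 2 gives 0.0833 h and compound 3 gives 0.1 h. Going by the values given here, the one single-point step measured is a 6.2-fold lower number from compound 1 to compound 2 (0.79 log units; beyond the scatter). Compound 3 stands second highest of the three numbers; it sits within the scatter of compound 2 and beyond the scatter below compound 1. Compound 4 `CC(C)CN1C(=O)CN(Cc2ccc(-c3ccc(F)c(CN4CCCCC4)n3)cc2)C1=O` differs from compound 3 by hydrogen in place of methyl on a saturated ring carbon. Among the compounds with values here, no measured step touches this position; the only step known concerns the chain on the amide-type nitrogen in a ring. In this assay compound 4 is therefore expected to show no step beyond the scatter, no change at the digits printed from compound 3 to compound 4 (within the scatter), with an estimate of 0.1 h and a range from 0.04 h to 0.25 h.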

Compound 4, half-life in the Rattus norvegicus assay: 0.15 h
The estimate for compound 4 lay 1.5-fold (0.18 log units) below the measured number; the measured number falls inside the stated range.
By their numbers in the Rattus norvegicus assay, from the lowest: compounds 2, 3 and 4 (each within the scatter of the next); then compound 1.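

In the Rattus norvegicus assay, a 1.5-fold higher number from compound 3 to compound 4 (0.18 log units; within the scatter), so replacing 3-methylpiperidin-1-yl with piperidin-1-yl leaves the half-life within the scatter, whereas in a physicochemical assay for lipophilicity (on this read-out lower numbers stand for lower lipophilicity and higher numbers for higher lipophilicity), compound 3 gives 3.9 and compound 4 gives 3.4. With piperidin-1-yl held constant, the Rattus norvegicus assay gives a 1.8-fold higher number from compound 2 to compound 4 (0.26 log units; within the scatter) and a 3.4-fold lower number from compound 1 to compound 4 (0.54 log units; beyond the scatter), so among these compounds the only steps beyond the scatter involve the methyl on the amide-type nitrogen of compound 1, not the ring methyl.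

From the compounds shown here alone, whether a hydroxyl, a fluorine or an ethyl on this ring carbon would behave like the methyl remains open.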